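The source may hold more compounds than are shown below. What is called first, only, known or untested is meant among the compounds shown, and "the series" means these compounds.

Compound 1 `CCOc1ccc2sc(S(C)(=O)=O)nc2c1S(=O)(=O)Nc1ccc([N+](=O)[O-])cc1`: in a functional assay on HeLa cells (Homo sapiens) for inhibition, read by sulforhodamine B assay, with a stated time of 48 h (on this read-out lower numbers stand for higher toxicity in this test and higher numbers for lower toxicity in this test), compound 1 gives 81500 nM.
Compound 2 `CCOc1ccc2sc(S(C)(=O)=O)nc2c1N`: in this assay compound 2 gives > 100000 nM, which is a limit of the assay rather than a number, as the limit of > 100000 nM in this assay, at which 1 of the 2 values shown sits, shows.

Compound 1 therefore holds the only actual number shown here, with the other value being a limit. Compound 3 `CCOc1ccc2sc(S(C)(=O)=O)nc2c1S(=O)(=O)Nc1ccc(Br)cc1` differs from compound 1 by bromo in place of nitro on an aromatic carbon. Among the compounds with values here, no step between two numbered compounds is available, so the size of this change remains open. A step from compound 1 to compound 3 of a 1.3-fold lower number from compound 1 to compound 3 (0.10 log units; within the scatter) is expected, staying within the usual scatter. Compound 3 is estimated at 65000 nM in this assay, with a likely range from 25000 nM to 150000 nM.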

Compound 3, concentration lethal to 50% of the cells: 74500 nM
Compound 3: middle estimate off by 1.1-fold (0.06 log units), on the low side; the range from low to high includes it.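

Bromo in place of nitro on an aromatic carbon gives a 1.1-fold lower number from compound 1 to compound 3 (0.04 log units; within the scatter) in this assay, the first step that can be read between two shown compounds. At this place, para to a large group, the exchange of a nitro for a single bromine atom, with two hydrogen-bond acceptors gone, therefore stays within the scatter.

From the compounds shown here alone, whether another group here, such as a carboxylic acid or an amine, would give a step beyond the scatter stays open. Compound 2 gives only a limit of the assay and not a number: the limit of > 100000 nM in this assay, at which 1 of the 3 values shown sits.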